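Adding a Phenoxy Group to the Most Potent Analogue

The compounds below may be only part of what the source reports. "The series", "measured", "known", "first", "only" and "open" are said of these compounds alone.

Compound 1 `N#Cc1ccc(Oc2cccnc2)cc1NCc1ccccc1` gives 986 nM in an assay on isolated protein for inhibition of Aromatase (Homo sapiens), read by fluorescence; a higher number here means a weaker inhibitor, a lower number a stronger inhibitor.
Compound 2 `N#Cc1ccc(-n2ccc3ccncc32)cc1` gives 93 nM in this assay.
Compound 3 `N#Cc1ccc(Oc2cccnc2)c(Oc2cccc(Cl)c2)c1` gives 229 nM in this assay.

Among these three numbers compound 2 stands lowest, and so is the strongest inhibitor of the set: compound 3 is nearest, its number a little higher and beyond the scatter, while compound 1 lies furthest away, far higher. Compound 4 `N#Cc1ccc(-n2ccc3ccncc32)cc1Oc1ccccc1` has not been measured yet. It keeps the whole of compound 2 and differs from it in one place only: phenoxy in place of hydrogen on an aromatic carbon.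

Going by the values given here, no pair among the measured compounds differs in a single place, so there is no measured step to lean on. Among the compounds with values here, compounds 1 and 3 carry other groups at the same sort of position on their own core, and their values sit apart from each other, but neither has a partner without that group, so they show no step for this kind of change. The expected step in this assay is therefore small and could go either way, most likely within the scatter. For compound 4 the estimate is 120 nM, with a range from 40 nM to 400 nM, meaning an expected step of a 1.3-fold higher number from compound 2 to compound 4 (0.11 log units; within the scatter).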

Compound 4, half-maximal inhibitory concentration: 114 nM
The estimate for compound 4 lay 1.1-fold (0.02 log units) above the measured number, within the range that was stated.
By their numbers in this assay, from the lowest: compounds 2, 4 and 3 (each within the scatter of the next, the first and the last beyond it); then compound 1.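

In this assay, going by these compounds alone, the first step between compounds differing in one place is a 1.2-fold higher number from compound 2 to compound 4 (0.09 log units; within the scatter), so a phenoxy group can take the place of hydrogen on this aromatic carbon, ortho to a cyano group, with no change that can be told from the scatter. Compounds 1 and 3 could not show this: each carries a group at the same sort of position on its own core, but neither has a partner without that group, whereas here a whole extra aromatic ring of seven heavy atoms is added and the number stays level with that of the parent. Why the value holds across so large an addition is not something the available data can explain, as no supporting measurement bears on it.

Going by these compounds, this is a single group at a single position, so it remains open whether a methoxy group, an amine or a carboxylic acid would be tolerated here in the same way. On these data alone, it also remains open whether a chlorine on the added phenoxy ring, or a benzylamino group in its place, would shift the number on this core.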